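Swapping Chloromethyl for 4-Chlorophenyl on an Amide Carbonyl

The compounds below may be only part of what the source reports. "The series", "measured", "known", "first", "only" and "open" are said of these compounds alone.

Of the compounds shown here, two have been tested in a functional assay on HepG2 cells (Homo sapiens) for cytotoxicity, read by MTT assay, with a stated time of 48 h; on this read-out lower numbers stand for stronger inhibition and higher numbers for weaker inhibition. Compound 2 `CNC(=O)CSc1nc2ccc(NC(=O)CCl)cc2s1` gives 1900 nM, the lowest number of the two. Compound 1 `COc1ccc(CNC(=O)CSc2nc3ccc(NC(=O)c4ccc(Cl)cc4)cc3s2)cc1`, which already carries a 4-chlorophenyl group on its amide carbonyl, gives 7400 nM, a higher number that lies beyond the scatter. Compound 3 `CNC(=O)CSc1nc2ccc(NC(=O)c3ccc(Cl)cc3)cc2s1` is compound 2 with 4-chlorophenyl in place of chloromethyl on a carbonyl carbon. Going by the values given here, no directly comparable pair has been measured, so the expectation rests on compound 1 showing the weaker number with that same group. Compound 3 is expected to move toward weaker inhibition, by an estimated 3.2-fold higher number from compound 2 to compound 3 (0.50 log units; beyond the scatter). The estimate for compound 3 is 6000 nM, within 2500 nM to 15000 nM.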

Compound 3, half-maximal inhibitory concentration: 15300 nM
Estimate against measurement, compound 3: 2.6-fold (0.41 log units) below, and the stated range ends below it.
By their numbers in this assay, from the lowest: compound 2; then compound 1; then compound 3.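

In this assay, the carbonyl carbon now has a direct pair: 4-chlorophenyl in place of chloromethyl gives an 8.1-fold higher number from compound 2 to compound 3 (0.91 log units; beyond the scatter) and so ties the larger group to weaker inhibition in this pair. A change elsewhere acts in the same direction, since hydrogen in place of 4-methoxyphenyl on a saturated chain carbon bound to an amide-type nitrogen gives a 2.1-fold higher number from compound 1 to compound 3 (0.32 log units; beyond the scatter) on this read-out. Nothing available explains either step. Still open, from the compounds shown here alone, is whether an amine or a longer chain on the carbonyl carbon would give a number closer to that of chloromethyl or of 4-chlorophenyl.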